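The source may hold more compounds than are shown below. What is called first, only, known or untested is meant among the compounds shown, and "the series" means these compounds.

Measured in a functional assay on HUVEC cells (Homo sapiens) for antiproliferative activity, read by MTT assay, with a stated time of 48 h; a higher number here means a weaker inhibitor, a lower number a stronger inhibitor:
- compound 1 `O=[N+]([O-])c1ccccc1/C=C/c1nnc(-c2ccc3c(c2)OCCO3)o1`: 25000 nM
- compound 2 `O=[N+]([O-])c1ccc(/C=C/c2nnc(-c3ccc4c(c3)OCCO4)o2)cc1`: 32100 nM
- compound 3 `Clc1ccccc1/C=C/c1nnc(-c2ccc3c(c2)OCCO3)o1`: 7710 nM

Compound 3 has the lowest number of the three, and its gaps to compound 1 and compound 2 both lie beyond the scatter. Compound 1 at 25000 nM and compound 2 at 32100 nM are within the scatter of each other.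

The next change leads to compound 4 `Cc1cccc(/C=C/c2nnc(-c3ccc4c(c3)OCCO4)o2)c1`: 3-methylphenyl in place of 2-chlorophenyl on a double-bonded chain carbon bound to a double-bonded chain carbon. In words, this is 3-methylphenyl in place of 2-chlorophenyl on a double-bonded chain carbon bound to a double-bonded chain carbon.

For the measured compounds named here, only one measured step bears on this change: a 3.2-fold lower number from compound 1 to compound 3 (0.51 log units; beyond the scatter), with chloro in place of nitro on an aromatic carbon. That step is modest, and it shows only that the substituent on this ring can move the number beyond the scatter. Going by the values given here, no measured compound carries a methyl group, so the size of the new step rests on thin evidence. A small move toward a higher number is expected, with compound 4 remaining closer to compound 3 at 7710 nM than to compound 1 at 25000 nM.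

The estimated step is a 1.4-fold higher number from compound 3 to compound 4 (0.15 log units; within the scatter), which is not expected to exceed the scatter.

For compound 4 the estimated value is 11000 nM, with an expected range of 4000 nM to 30000 nM.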

Compound 4, half-maximal inhibitory concentration: 40600 nM
For compound 4 the middle estimate is 3.7-fold (0.57 log units) below the measured one; the measured number lies above the stated range.
By their numbers in this assay, from the lowest: compound 3; then compounds 1, 2 and 4 (each within the scatter of the next).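

In this assay, the move to 3-methylphenyl gives a 5.3-fold higher number from compound 3 to compound 4 (0.72 log units; beyond the scatter), which shows that the low number of compound 3 does not carry over to every non-nitro aryl group on this double-bonded chain carbon. The 2-chlorophenyl and 3-methylphenyl groups have the same count of 7 heavy atoms and no hydrogen-bond donors or acceptors, so these counts do not track the step, and among the four compounds only compound 3 stands apart, while compounds 1, 2 and 4 lie each within the scatter of the next. Nothing available on these compounds explains the step.

As far as these compounds go, the change replaces the substituent and its ring place in one move, so the part played by each stays open until 2-methylphenyl and 3-chlorophenyl analogues can be compared with compound 3 and compound 4. Also open, from the compounds shown here alone, is how an amine or a carboxylic acid on this ring would read in this assay.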